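A few compounds are considered here, and "the series" means these few. Any claim that something is new, unique, unknown or untested is made for them only; others in the source may bear on it.

Compound 1 `N#CC1=C(N)N(c2ccc(S(N)(=O)=O)cc2)C2=C(C(=O)CCC2)C1/C=C/c1ccccc1`: 40%
Compound 2 `COc1ccccc1C1C(C#N)=C(N)N(c2ccc(S(N)(=O)=O)cc2)C2=C1C(=O)CCC2`: 0%
Compound 3 `COc1ccc(C2C(C#N)=C(N)N(c3ccc(S(N)(=O)=O)cc3)C3=C2C(=O)CCC3)cc1`: 90%

All three share one core and differ only in the group on a saturated ring carbon. In a functional assay on Ehrlich cells (Mus musculus) for antiproliferative activity, read by trypan blue exclusion, with a stated time of 2 h, tested at 50 ug/mL (a lower number here means a weaker effect, a higher number a stronger effect of the compound at the concentration tested), compound 3 stands highest of the three numbers, with compound 1 nearest and compound 2 furthest. Compound 4 `N#CC1=C(N)N(c2ccc(S(N)(=O)=O)cc2)C2=C(C(=O)CCC2)C1c1ccc(Cl)cc1Cl` is the next step: 2,4-dichlorophenyl in place of 4-methoxyphenyl on a saturated ring carbon. Within the data shown here, the steps that bear on it all change the same position: a number 90 percentage points higher from compound 2 to compound 3 (beyond the scatter), a number 50 percentage points higher from compound 1 to compound 3 (beyond the scatter) and a number 40 percentage points lower from compound 1 to compound 2 (beyond the scatter). Among the measured compounds shown here, no measured step involves a chlorine-bearing ring, so the direction is open; the position is clearly sensitive. For compound 4 a drop of moderate size is expected, a number 40 percentage points lower from compound 3 to compound 4 (beyond the scatter), with wide uncertainty. Compound 4 is therefore estimated at 50%, in the range 10% to 90%.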

Compound 4, a percentage reported as activity, at one concentration (the size of the read-out at that concentration, not a potency): 65%
Beside the measured number, compound 4's estimate is 15 percentage points below it; the measured number falls inside the stated range.
By their numbers in this assay, from the lowest: compound 2; then compound 1; then compound 4; then compound 3.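

In this assay a chlorine-bearing ring on this saturated ring carbon keeps much of the effect, with 2,4-dichlorophenyl giving a number 65 percentage points higher from compound 2 to compound 4 (beyond the scatter) and a number 25 percentage points higher from compound 1 to compound 4 (beyond the scatter) but also a number 25 percentage points lower from compound 3 to compound 4 (beyond the scatter). Compound 3 with its 4-methoxyphenyl thus stays highest of the four, while 2,4-dichlorophenyl and 2-methoxyphenyl lie far apart. No evidence given here accounts for these differences. The compounds shown leave open what each chlorine contributes separately, and whether 4-chlorophenyl or 4-aminophenyl would match 4-methoxyphenyl.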